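Amine swap in the tethered side chain and solubility

The source may report more compounds than this note shows. Statements on the series, on what has been measured and on what is new or still open speak of the compounds shown alone.

Three measured compounds share one core. In a physicochemical assay for solubility, read by spectrophotometry, in phosphate buffer, with a stated time of 2 h, at pH 7.4 (a lower number here means a less soluble compound, a higher number a more soluble compound), compound 1 `COc1ccc2[nH]c(C(=O)N3CC(=O)N(Cc4ccccc4)[C@@H](CCN4CCC5(CC4)CC5)C3)cc2c1` gives > 25000 nM, which is a limit of the assay (the limit of > 25000 nM in this assay, at which 1 of the 3 values shown sits). Compound 2 `COc1ccc2[nH]c(C(=O)N3CC(=O)N(Cc4ccccc4)[C@@H](CN4CC5CC5C4)C3)cc2c1` gives 17500 nM in this assay. Compound 3 `COc1ccc2[nH]c(C(=O)N3CC(=O)N(Cc4ccccc4)[C@@H](CN4CCn5cccc5C4)C3)cc2c1` gives 29700 nM in this assay; its nearest neighbour among the numbers is compound 2, and the step of a 1.7-fold higher number from compound 2 to compound 3 (0.23 log units; within the scatter) lies within the scatter. The step of an at least 1.4-fold lower number from compound 1 to compound 2 (0.15 log units; that floor lies within the scatter) adds no readable size, and the step that the limit leaves unreadable from compound 1 to compound 3 cannot be read at all. Compound 4 `COc1ccc2[nH]c(C(=O)N3CC(=O)N(Cc4ccccc4)[C@@H](CN4CCc5ccccc5C4)C3)cc2c1` differs from compound 3 by a group of 10 heavy atoms (9 carbon, 1 nitrogen; one six-membered non-aromatic ring with 1 hetero atom, one six-membered aromatic ring of carbon only) in place of a group of 9 heavy atoms (7 carbon, 2 nitrogen; one five-membered aromatic ring with 1 hetero atom, one six-membered non-aromatic ring with 2 hetero atoms), on a saturated chain carbon bound to a saturated ring carbon. Since every measured change at this position stayed within the scatter, no step beyond it is expected in this assay. In this assay compound 4 is expected near 20000 nM, with a range from 8000 nM to 45000 nM. The expected step of a 1.5-fold lower number from compound 3 to compound 4 (0.17 log units; within the scatter) thus stays within the scatter.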

Compound 4, solubility: 9000 nM
Compound 4: the middle estimate sits 2.2-fold (0.35 log units) above what was measured; the measured number falls inside the stated range.
By their numbers in this assay, from the lowest: compounds 4, 2 and 3 (each within the scatter of the next, the first and the last beyond it).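

In this assay, within the data shown here, the 1,2,3,4-tetrahydroisoquinolin-2-yl group gives the first readable change at this position that clears the scatter: a 3.3-fold lower number from compound 3 to compound 4 (0.52 log units; beyond the scatter). The step of a 1.9-fold lower number from compound 2 to compound 4 (0.29 log units; within the scatter) stays within it. The step of an at least 2.7-fold lower number from compound 1 to compound 4 (0.44 log units; beyond the scatter) also clears it, but it rests on compound 1, whose value is a limit: the limit of > 25000 nM in this assay, at which 1 of the 4 values shown sits.

From the compounds shown here alone, how a morpholine or a piperazine on this saturated chain carbon would read in this assay stays open. Also open, going by these compounds, is whether the six-membered aromatic ring of carbon only goes with the lower number in other amines.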